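The source may report more compounds than this note shows. Statements on the series, on what has been measured and on what is new or still open speak of the compounds shown alone.

Working notes on the series. In a functional assay on the whole organism (strain albino) for inhibition, with Rattus norvegicus as the target, read by paw edema, in the formalin test, with a stated time of 1 h, at a dose of 10 mg/kg by the oral route (on this read-out higher numbers stand for more inhibition at the one dose given (going by the name of the read-out) and lower numbers for less inhibition), compound 1 `Cc1c(C(N)=O)sc2nc(N/N=C/c3ccc(Br)cc3)n(Cc3ccccc3)c(=O)c12` gives 69% and compound 2 `Cc1cc(C)n(-c2nc3sc(C(N)=O)c(C)c3c(=O)n2Cc2ccccc2)n1` gives 44%. Among the measured compounds shown here, on these two numbers compound 2 stands lowest, with compound 1 as its only neighbour; the one measured step, a number 25 percentage points lower from compound 1 to compound 2 (beyond the scatter), changes the group on the aromatic carbon between two ring nitrogen atoms of the shared core. Compound 3 `CC1=NN(c2nc3sc(C(N)=O)c(C)c3c(=O)n2Cc2ccccc2)C(=O)C1` differs from compound 2 at the same place: a group of 7 heavy atoms (4 carbon, 2 nitrogen, 1 oxygen; one five-membered non-aromatic ring with 2 hetero atoms) in place of a group of 7 heavy atoms (5 carbon, 2 nitrogen; one five-membered aromatic ring with 2 hetero atoms), on an aromatic carbon. For the measured compounds named here, no measured step replaces an aromatic five-membered ring here by a non-aromatic one, so the step from compound 1 to compound 2 bears on it only in showing that the group at this position moves the read-out by a modest amount. A step from compound 2 to compound 3 of about a number 2 percentage points lower from compound 2 to compound 3 (within the scatter) is expected, within the scatter, with no direction preferred. Compound 3 is therefore expected to give 42% in this assay, in a range from 22% to 62%.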

Compound 3, a percentage reported as inhibition, in the whole organism at one dose (the size of the read-out at that dose, not a potency): 37%
Beside the measured number, compound 3's estimate is 5 percentage points above it; the range from low to high includes it.
By their numbers in this assay, from the lowest: compounds 3 and 2 (each within the scatter of the next); then compound 1.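

In this assay the step from the 3,5-dimethyl-1H-pyrazol-1-yl group to the non-aromatic five-membered ring is a number 7 percentage points lower from compound 2 to compound 3 (within the scatter), so on this read-out the two rings at this aromatic carbon cannot be told apart. Each ring also stands clear of the group of compound 1: a number 25 percentage points lower from compound 1 to compound 2 (beyond the scatter), and likewise a number 32 percentage points lower from compound 1 to compound 3 (beyond the scatter), so the larger change at this position is the departure from that group, and ring aromaticity adds nothing beyond the scatter. No measurement offered here explains either step.

On these data alone, it remains open whether the bromine of compound 1 contributes to its higher number, as a chlorine or plain phenyl analogue would test. As far as these compounds go, how a simple amine or a carboxylic acid at this carbon would read also remains open.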